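Replacing a methylated phenyl by a naphthalene on the hydrazone

The compounds below may be only part of what the source reports. "The series", "measured", "known", "first", "only" and "open" are said of these compounds alone.

Compound 1, with the structure `CCCSc1nc(N/N=C/c2ccc(C)cc2)c2nnn(Cc3ccccc3)c2n1`, was tested in a functional assay on ECa-109 cells (Homo sapiens) for antiproliferative activity, read by MTT assay, with a stated time of 72 h; a higher number here means a weaker inhibitor, a lower number a stronger inhibitor. In this assay compound 1 gives only a limit, > 64000 nM, which is not a measured number. That limit is where compound 1 stands, as the evidence shows: the limit of > 64000 nM in this assay, at which 1 of the 2 values shown sits. A second compound, compound 2, with the structure `C#CCSc1nc(N/N=C/c2cc(OC)c(OC)c(OC)c2)c2nnn(Cc3ccccc3)c2n1`, differs from compound 1 in more than one place, and in this assay compound 2 gives 6540 nM, a number rather than a limit.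

Compound 3, with the structure `CCCSc1nc(N/N=C/c2ccc3ccccc3c2)c2nnn(Cc3ccccc3)c2n1`, is not yet measured. It differs from compound 1 in one place: naphthalen-2-yl in place of 4-methylphenyl on a carbon with a double bond to nitrogen. Within the data shown here, no measured pair of compounds follows this exact change, so there is no direct guide to its effect. The step from compound 1 to compound 3 is expected to be small, an at least 1.0-fold lower number from compound 1 to compound 3 (0.02 log units; that floor lies within the scatter). Compound 3 is therefore expected to give about 60000 nM, within a range from 15000 nM to 200000 nM.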

Compound 3, half-maximal inhibitory concentration: > 64000 nM
Compound 3 was reported as a limit; the forecaster's own chance of this, stated with the estimate: 60%; middle value at least 1.0-fold (0.02 log units) from the limit.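

In this assay compound 3 gives > 64000 nM, which is a limit and not a number. Among these compounds, compound 1 is also reported as a limit, and no step between compound 1 and compound 3 can be read. Going by these compounds, how naphthalen-2-yl compares with 4-methylphenyl in antiproliferative activity stays open.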